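Working notes on the aryl exchange in the shared core

The source may hold more compounds than are shown below. What is called first, only, known or untested is meant among the compounds shown, and "the series" means these compounds.

Measured so far:
compound 1 `CC1=C(C(=O)OC2CCCCC2)C(c2cccc(Br)c2)C2=C(CC(C)(C)CC2=O)N1`, 4150 nM
compound 2 `CC1=C(C(=O)OC2CCN(C(=O)OC(C)(C)C)CC2)C(c2cccc(Br)c2)C2=C(CC(C)(C)CC2=O)N1`, limit > 10000 nM
compound 3 `CC1=C(C(=O)OCC2CCN(C(=O)OC(C)(C)C)CC2)C(c2ccc3c(c2)OCCO3)C2=C(CC(C)(C)CC2=O)N1`, 1520 nM

In an assay on HEK293 cells for inhibition of neurogenic locus notch homolog protein 1 (Homo sapiens), read by a luciferase reporter and resazurin assay, with a stated time of 16 h (a higher number here means a weaker inhibitor, a lower number a stronger inhibitor), compound 3 gives the lowest of the two numbers shown; compound 1 gives a higher number, a gap beyond the scatter. For compound 2 this assay reports only a limit, (the limit of > 10000 nM in this assay, at which 1 of the 3 values shown sits).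

Compound 4 `CC1=C(C(=O)OCC2CCN(C(=O)OC(C)(C)C)CC2)C(c2cccc(C(F)(F)F)c2)C2=C(CC(C)(C)CC2=O)N1` carries 3-(trifluoromethyl)phenyl in place of 2,3-dihydro-1,4-benzodioxin-6-yl on a saturated ring carbon. Among the compounds with values here, no pair of measured compounds isolates this exchange, so no measured step guides it. A step of moderate size is expected, a 1.6-fold higher number from compound 3 to compound 4 (0.22 log units; within the scatter), towards a weaker inhibitor, with room for none beyond the scatter. Compound 4 is estimated at 2500 nM, within 800 nM to 8000 nM.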

Compound 4, half-maximal inhibitory concentration: 760 nM
Compound 4: middle estimate off by 3.3-fold (0.52 log units), on the high side; measured number outside the range, below it.
By their numbers in this assay, from the lowest: compounds 4 and 3 (each within the scatter of the next); then compound 1. At a limit, above all of these: compound 2.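

In this assay the exchange gives a 2.0-fold lower number from compound 3 to compound 4 (0.30 log units; within the scatter) and so does not separate 3-(trifluoromethyl)phenyl from 2,3-dihydro-1,4-benzodioxin-6-yl on this saturated ring carbon. With the ester of compound 3 held fixed, this carbon thus carries an aryl group with 0 hydrogen-bond acceptors or one with 2, and the two read alike. Nothing shown bears on a cause for this step.

Open remains how a phenyl carrying an amine or a carboxylic acid reads on this carbon. Also open, from the compounds shown here alone, is whether the same exchange reads alike with the ester groups of compound 1 and compound 2.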